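Swapping the ethynylpyridine group of compound 2

The compounds below may be only part of what the source reports. "The series", "measured", "known", "first", "only" and "open" are said of these compounds alone.

Compound 1 `C=Cc1ccnc(C#Cc2ccc3ncn(-c4ccnc(N)n4)c3c2)c1`: 398 nM
Compound 2 `C#Cc1ccnc(C#Cc2ccc3ncn(-c4ccnc(N)n4)c3c2)c1`: 7940 nM
Compound 3 `C=Cc1ccnc(C#Cc2ccc3ncn(-c4ccnc(N)n4)c3c2)n1`: not yet measured

In a functional assay on Z-138 cells (Homo sapiens) for inhibition, read by XTT assay, with a stated time of 72 h (a lower number here means a stronger inhibitor of growth, a higher number a weaker inhibitor of growth), compound 2 gives 7940 nM, the higher of the two numbers. Compound 3 replaces its 4-ethynylpyridin-2-yl group: a group of 8 heavy atoms (6 carbon, 2 nitrogen; one six-membered aromatic ring with 2 hetero atoms) in place of a group of 8 heavy atoms (7 carbon, 1 nitrogen; one six-membered aromatic ring with 1 hetero atom), on a triple-bonded carbon. The triple bond outside the aromatic ring gives way to a double bond. Among the compounds with values here, one measured step bears on this, a 20-fold higher number from compound 1 to compound 2 (1.30 log units; beyond the scatter), which is large and arose from ethynyl in place of vinyl. Here the change runs the opposite way, but no measured step tests the ring with 2 hetero atoms. A lower number is therefore expected, an estimated 8.8-fold lower number from compound 2 to compound 3 (0.95 log units; beyond the scatter). For compound 3 the estimate is 900 nM, with an expected range of 200 nM to 4000 nM.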

Compound 3, concentration for 50% growth inhibition: 1000 nM
Compound 3: the middle estimate sits 1.1-fold (0.05 log units) below what was measured; low and high end bracket the measured number.
By their numbers in this assay, from the lowest: compound 1; then compound 3; then compound 2.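

In this assay, there is a modest loss of growth inhibition, a 2.5-fold higher number from compound 1 to compound 3 (0.40 log units; beyond the scatter), with the vinyl group kept and the ring changed to one with 2 hetero atoms. The other step, a 7.9-fold lower number from compound 2 to compound 3 (0.90 log units; beyond the scatter), changes the ring and replaces ethynyl with vinyl at once, so it cannot show how much each change contributes. No measurement here explains either step. The compounds shown leave open how the ring with 2 hetero atoms behaves with ethynyl attached. They also leave open whether an amine or a longer chain in place of vinyl would keep growth inhibition.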